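The source may hold more compounds than are shown below. What is called first, only, known or untested is meant among the compounds shown, and "the series" means these compounds.

Compounds measured so far:

Compound 1 `COc1ccc(COc2ccc3c(Cn4ccnc4)cc(=O)oc3c2)cc1OC` — 57 nM
Compound 2 `O=c1cc(Cn2ccnc2)c2ccc(OCc3cc(F)cc(F)c3)cc2o1` — 45 nM

Both compounds were tested in an assay on V79MZh11B1 cells for inhibition of cytochrome P450 11B1, mitochondrial (Homo sapiens), read by HPLC, with a stated time of 25 min; a lower number here means a stronger inhibitor, a higher number a weaker inhibitor. In this assay compound 1 gives 57 nM, and compound 2 gives 45 nM. The gap between the two numbers falls within the scatter of repeated measurements, so the two compounds cannot be told apart on these data; compound 2 simply sits in the same range as compound 1.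

Compound 3 `O=c1cc(Cn2ccnc2)c2ccc(OCc3cccc(F)c3)cc2o1` is the next compound, not yet measured. It is made from compound 2 by one change: hydrogen in place of fluoro on an aromatic carbon. Put another way, the difluorobenzyl ether of compound 2 becomes a monofluorobenzyl ether, while the rest of the shared core and the imidazolylmethyl arm stay untouched.

Among the compounds with values here, no measured pair in this set differs by such a fluorine-for-hydrogen swap, so there is no directly comparable step to lean on. Losing a single fluorine with no change in donors, acceptors or charge is expected to move the number only a little, and the expected step from compound 2 to compound 3 is a 1.3-fold higher number from compound 2 to compound 3 (0.12 log units; within the scatter), which is within the scatter. Compound 3 is therefore estimated at 60 nM, with a likely range from 25 nM to 150 nM.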

Compound 3, half-maximal inhibitory concentration: 40 nM
For compound 3 the middle estimate is 1.5-fold (0.18 log units) above the measured one; measured number inside the range.
By their numbers in this assay, from the lowest: compounds 3, 2 and 1 (each within the scatter of the next).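

In this assay, taking one fluoro off the 3,5-difluorobenzyl group to leave the 3-fluorobenzyl group gives a 1.1-fold lower number from compound 2 to compound 3 (0.05 log units; within the scatter), so compound 2 and compound 3 cannot be told apart. Within the data shown here, this is the first pair in the set that differs in one place only, so it isolates what the comparison of compound 1 with compound 2 could not: the effect of a single atom on this aromatic carbon, with the shared core, the imidazolylmethyl arm and the rest of the benzyl ether held constant. On this evidence, hydrogen and fluoro are interchangeable at this one position on this one compound, and nothing available offers an explanation for that result.

One swap of a small atom says little about how much change this aromatic carbon can accept, so a chloro, a trifluoromethyl, an amine or a carboxylic acid placed there could behave quite differently. As far as these compounds go, it also remains open whether the plain benzyl ether, with no fluoro on the ring at all, would stay in the same range as compound 3.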